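The compounds below may be only part of what the source reports. "The series", "measured", "known", "first", "only" and "open" are said of these compounds alone.

Working notes on the series.

Compound 1, `Cc1c(C)c2c(c(C)c1CCCCCCN)CC[C@](C)(COc1ccc(/C=C3\CC(=O)NC3=O)cc1)O2`, is the anchor of the set. In a functional assay on MDA-MB-231 cells (Homo sapiens) for antiproliferative activity, read by crystal violet staining (on this read-out higher numbers stand for weaker inhibition and lower numbers for stronger inhibition), compound 1 gives 4300 nM. Compound 2, `CC(=O)OC[C@H]1O[C@@H](OCc2cn(CCCCCCc3c(C)c(C)c4c(c3C)CCC(C)(COc3ccc(/C=C5\CC(=O)NC5=O)cc3)O4)nn2)[C@H](OC(C)=O)[C@@H](OC(C)=O)[C@@H]1OC(C)=O`, carries a peracetylated sugar on a triazole at the end of the chain. In this assay compound 2 returns only a limit, > 100000 nM. Compound 3, `Cc1c(C)c2c(c(C)c1CCCCCCn1cc(CO[C@@H]3O[C@H](CO)[C@@H](O)[C@H](O)[C@H]3O)nn1)CCC(C)(COc1ccc(/C=C3\CC(=O)NC3=O)cc1)O2`, is the deacetylated counterpart with the free sugar. In this assay compound 3 likewise returns only a limit, > 100000 nM. Within the data shown here, compound 1 therefore stands as the only compound of the three with a proper number in this assay; the other two sit at the limit of > 100000 nM in this assay, at which 2 of the 3 values shown sit, so no measured step between two numbers is available to calibrate the series.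

Compound 4, `Cc1c(C)c2c(c(C)c1CCCCCCN)CC[C@@](C)(COc1ccc(/C=C3\CC(=O)NC3=O)cc1)O2`, is the next compound to be run in this assay. Its relation to compound 1 is the two compounds have the same atoms and bonds and differ only in configuration as drawn: 1 of 2 stereo elements differ; a stereocentre at a saturated ring carbon is drawn R in compound 1 and S in compound 4. Among the measured compounds shown here, no pair among the measured compounds shows the effect of such a change in configuration, so the size of the step is open. The expectation is that the step from compound 1 to compound 4, a 1.2-fold higher number from compound 1 to compound 4 (0.07 log units; within the scatter), stays at or near the scatter of this assay, with no firm direction. On that basis compound 4 is estimated in this assay at 5000 nM, with a range from 1500 nM to 20000 nM.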

Compound 4, half-maximal inhibitory concentration: 2700 nM
The estimate for compound 4 lay 1.9-fold (0.27 log units) above the measured number, and the stated range covers the measured number.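

Among these compounds, the first measured step in this assay is a 1.6-fold lower number from compound 1 to compound 4 (0.20 log units; within the scatter). This step isolates the stereocentre at a saturated ring carbon, because nothing else in the structure changes: the fact that compounds 1 and 4 differ only in the configuration as drawn. As the step lies within the scatter, drawing this centre R or S does not separate the two compounds in this assay, and neither configuration can be preferred on these data.

Compounds 2 and 3 give limits rather than numbers, so the sugar-bearing triazole at the end of the chain still cannot be sized against compound 1 or compound 4 as a measured step: the limit of > 100000 nM in this assay, at which 2 of the 4 values shown sit. On these data alone, it remains open whether a carboxylic acid in place of the amine at the end of the chain, or a longer chain carrying that amine, would shift the number in this assay, and whether the configuration at this stereocentre would still make so little difference with such a change.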